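From methoxycarbonyl to ethoxycarbonyl at the limit

A few compounds are considered here, and "the series" means these few. Any claim that something is new, unique, unknown or untested is made for them only; others in the source may bear on it.

In a functional assay on the whole organism for agonist activity, with Mus musculus as the target (a higher number here means that more compound is needed for the effect, a lower number that less compound is needed), the measured compounds stand as follows:
- compound 1 `COC(=O)N(C)C(C)C#CCn1ccnc1` gives 8 mg/kg
- compound 2 `COC(=O)N(C)C(C)C#CCn1cncc1C` gives > 100 mg/kg (a limit)

Compound 2 gives > 100 mg/kg as a limit and not as a number. Compound 3 `CCOC(=O)N(C)C(C)C#CCn1cncc1C` differs from it by methyl in place of hydrogen on a saturated chain carbon bound to an oxygen next to a carbonyl group at one place, with methyl in place of hydrogen on a saturated chain carbon bound to an oxygen next to a carbonyl group. Going by the values given here, the only measured step of an at least 12-fold higher number from compound 1 to compound 2 (1.09 log units; beyond the scatter) was large, but it is methyl in place of hydrogen on an aromatic carbon, so it gives no size for this change. The estimated step that the limit leaves unreadable from compound 2 to compound 3 is expected to stay within the scatter. For compound 3 the expected dose in this assay is 120 mg/kg with an estimated range from 50 mg/kg to 300 mg/kg. A limit rather than a number may well be expected for compound 3.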

Compound 3, dose for half-maximal effect: > 100 mg/kg
Compound 3: a limit, no number; the forecaster's own chance of this, stated with the estimate: 70%; the middle value lies beyond the limit too.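

In this assay, going by these compounds alone, compound 2 and compound 3 both stand at a limit and not at a number, so no step between them can be read: the limit of > 100 mg/kg in this assay, at which 2 of the 3 values shown sit. The compounds shown leave open whether methoxycarbonyl to ethoxycarbonyl changes the dose at all.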